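Tetrazole to tetrazolylmethyl switch on two related cores

A few compounds are considered here, and "the series" means these few. Any claim that something is new, unique, unknown or untested is made for them only; others in the source may bear on it.

Compound 1 `c1cc(OCc2ccc(-c3nn[nH]n3)cc2)cc(OCc2ccc3ccccc3n2)c1` gives 12 nM in a functional assay (lung) for inhibition, with Cavia porcellus as the target; on this read-out higher numbers stand for weaker inhibition and lower numbers for stronger inhibition. Compound 3 `c1cc(OCc2ccc(Cc3nnn[nH]3)cc2)cc(OCc2ccc3ccccc3n2)c1` carries the change (1H-tetrazol-5-yl)methyl in place of 2H-tetrazol-5-yl on an aromatic carbon and gives 20 nM in this assay; the step is a 1.7-fold higher number from compound 1 to compound 3 (0.22 log units; within the scatter). Compound 2 `c1cc(OCc2ccc3ccccc3n2)cc(OCc2ccccc2-c2nn[nH]n2)c1` is built from the same atoms as compound 1, joined differently; the difference between the two cores is not broken down here. In this assay compound 2 gives 19 nM, a value that sits within the scatter of both compound 1 and compound 3. Compound 4 `c1cc(OCc2ccc3ccccc3n2)cc(OCc2ccccc2Cc2nnn[nH]2)c1` has not been measured. It stands to compound 2 as compound 3 stands to compound 1, the change being ((1H-tetrazol-5-yl)methyl in place of 2H-tetrazol-5-yl on an aromatic carbon); the two places differ in that here the group sits ortho to a large group, whereas on the core of compound 1 it sits para to a large group, so it is the same kind of change, not the same one. Resting on that single earlier example, the new step is expected to be a 1.6-fold higher number from compound 2 to compound 4 (0.20 log units; within the scatter), matching a 1.7-fold higher number from compound 1 to compound 3 (0.22 log units; within the scatter) in size, because a 1.7-fold higher number from compound 1 to compound 3 (0.22 log units; within the scatter) stayed within the scatter. Compound 4 is accordingly estimated at 30 nM, with a range from 12 nM to 75 nM that allows for the untested place.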

Compound 4, half-maximal inhibitory concentration: 9.5 nM
Compound 4: middle estimate off by 3.2-fold (0.50 log units), on the high side, outside the stated range (below it).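

In this assay the new step is a 2.0-fold lower number from compound 2 to compound 4 (0.30 log units; within the scatter), and the same change does not carry over as one fixed step from one core to the other: the same change on two cores in this assay, a 1.7-fold higher number (0.22 log units; within the scatter) from compound 1 to compound 3 and a 2.0-fold lower number (0.30 log units; within the scatter) from compound 2 to compound 4, 3.3-fold (0.52 log units) apart, beyond the scatter of two such steps. Taken singly, neither step leaves the scatter, so replacing 2H-tetrazol-5-yl with (1H-tetrazol-5-yl)methyl is tolerated on both cores, and only the gap between the two steps goes beyond it. Each core supplies a single pair, so the data give no reason for the gap and do not tell whether the place ortho to a large group is what sets the cores apart, nor whether the gap would recur on a further core.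

Open, from the compounds shown here alone, is whether a longer chain, such as (1H-tetrazol-5-yl)ethyl, continues the divergence between the two cores in this assay. Also open, going by these compounds, is whether a carboxylic acid in place of the tetrazole, directly on the ring or through a methylene, would show the same dependence on the core.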